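The source may hold more compounds than are shown below. What is called first, only, known or untested is meant among the compounds shown, and "the series" means these compounds.

Two analogues built on a shared core have been measured in an assay on FRT-Jurkat cells for inhibition of nuclear factor NF-kappa-B complex (Homo sapiens), read by flow cytometry, with a stated time of 24 h, tested at 10 uM; a higher number here means more inhibition at the concentration tested (going by the name of the read-out), a lower number less inhibition. Compound 1, `CCCc1ccc(Nc2ccc3c(c2)C(=O)N(C2CCC(=O)NC2=O)C3=O)cc1`, gives 10% in this assay. Compound 2, `Cc1ccc(Nc2cccc3c2C(=O)N(C2CCC(=O)NC2=O)C3=O)cc1`, gives 9%. Compound 2 thus holds the lower of the two recorded numbers, but the nearest value, that of compound 1, lies within the usual scatter of it, so no order can be read between the two; both simply show weak inhibition at the tested concentration. The next compound, compound 3, `CCCc1ccc(Nc2cccc3c2C(=O)N(C2CCC(=O)NC2=O)C3=O)cc1`, has not yet been measured in this assay. It differs from compound 2 in a single place: ethyl in place of hydrogen on a saturated chain carbon bound to an aromatic carbon. Among the measured compounds shown here, no step between measured compounds that differ in one place is available, so the outlook rests on the fact that compound 1 with 10% and compound 2 with 9% sit at the same low level. Compound 3 is therefore expected to remain there, with an expected step of a number 1 percentage points higher from compound 2 to compound 3 (within the scatter) amounting to none beyond the scatter. The estimate for compound 3 in this assay is 10%, within a range from 0% to 25%.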

Compound 3, a percentage reported as inhibition, at one concentration (the size of the read-out at that concentration, not a potency): 23%
For compound 3 the middle estimate is 13 percentage points below the measured one; the measured number falls inside the stated range.
By their numbers in this assay, from the lowest: compounds 2 and 1 (each within the scatter of the next); then compound 3.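

In this assay, the change from 4-methylphenyl to 4-propylphenyl gives a number 14 percentage points higher from compound 2 to compound 3 (beyond the scatter). Among the compounds shown here, this is the first step to go beyond the scatter, and it shows that the read-out responds to ethyl in place of hydrogen on this saturated chain carbon bound to an aromatic carbon, although the step is modest and inhibition at the tested concentration stays partial. The 4-propylphenyl group alone does not bring this rise, as compound 1 also carries it and gives 10%, whereas compound 3 gives 23%, so the gain appears only with the arrangement on the shared core found in compound 2 and compound 3, and nothing available explains this result.

The compounds shown leave open whether the read-out keeps rising along the chain, as a 4-butylphenyl or 4-pentylphenyl group would test, or whether a 4-ethylphenyl group would already reach the level of compound 3. They also leave open whether the chain must be purely carbon, or whether one ending in an amine or a carboxylic acid would hold or lose the gain.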